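This account rests on a few compounds, and the source may have more. Where it says the series, first, only, none or still open, it means among the compounds named here.

Measured so far in an assay on HEK293 cells for inhibition of SCN8A/SCN1B (Homo sapiens), read by patch clamp, with a stated time of 20 min; on this read-out higher numbers stand for weaker inhibition and lower numbers for stronger inhibition:
compound 1, `C[C@H](Nc1cc(F)c(S(=O)(=O)Nc2cscn2)cc1Cl)c1ccccc1`, 650 nM
compound 2, `COc1ccc(F)c([C@H](C)Nc2cc(F)c(S(=O)(=O)Nc3cscn3)cc2Cl)c1`, 110 nM
compound 3, `C[C@H](Nc1cc(F)c(S(=O)(=O)Nc2cscn2)c(F)c1)c1ccccc1F`, 60 nM

Compound 3 gives the lowest number of the three; its gap to compound 2 lies within the scatter, its gap to compound 1 beyond it. Compound 4, `COc1ccc(F)c([C@H](C)Nc2cc(F)c(S(=O)(=O)Nc3cscn3)c(F)c2)c1`, is not yet measured. It differs from compound 3 by methoxy in place of hydrogen on an aromatic carbon. Among the measured compounds shown here, the only measured step that touches this part of the molecule is a 5.9-fold lower number from compound 1 to compound 2 (0.77 log units; beyond the scatter), which brought in a fluoro group and a methoxy group at once, so the share of the methoxy alone cannot be separated out. Compound 2 and compound 3 sit within the scatter of each other. For compound 4 a small lowering is expected, a 1.7-fold lower number from compound 3 to compound 4 (0.23 log units; within the scatter). The estimate for compound 4 is 35 nM, range 15 nM to 80 nM.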

Compound 4, half-maximal inhibitory concentration in the SCN8A/SCN1B assay: 70 nM
For compound 4 the middle estimate is 2.0-fold (0.30 log units) below the measured one; the range from low to high includes it.
By their numbers in the SCN8A/SCN1B assay, from the lowest: compounds 3, 4 and 2 (each within the scatter of the next); then compound 1.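

Methoxy on this aromatic carbon, para to a fluoro group, can now be read alone on the 2-fluorophenyl compounds: in the SCN8A/SCN1B assay compound 3 gives 60 nM and compound 4 gives 70 nM and the step (a 1.2-fold higher number from compound 3 to compound 4 (0.07 log units; within the scatter)) does not separate the pair. In a physicochemical assay for lipophilicity, read by LC-MS, in phosphate buffer, measured as octanol-water partition, with a stated time of 1 h, at pH 7.4 (a higher number here means a more lipophilic compound, a lower number a more polar compound), compound 3 gives 2.9 and compound 4 gives 2.9 and the same change also leaves the pair unseparated (no change at the digits printed from compound 3 to compound 4 (within the scatter)). No evidence on the cause of either result is available.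

On these data alone, the share of methoxy alone on the core of compound 2 remains open. So does whether an amine, a carboxylic acid or a longer alkoxy chain on this carbon would separate from hydrogen.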